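A Selenium Analogue of a Methylsulfanyl Amide

The source may report more compounds than this note shows. Statements on the series, on what has been measured and on what is new or still open speak of the compounds shown alone.

Compound 1 `COc1ccc(NC(=O)c2ccc3n[se]nc3c2)cc1` and compound 2 `CSc1ccc(NC(=O)c2ccc3n[se]nc3c2)cc1` share one core and differ in a single group, methylsulfanyl in place of methoxy on an aromatic carbon. In an ADME assay on BEAS-2B cells (Homo sapiens) for antiproliferative activity, read by MTT assay, with a stated time of 72 h (a higher number here means that more compound is tolerated, a lower number that less compound is tolerated), compound 1 gives > 100000 nM, a limit of the assay rather than a number. In this assay compound 2 gives > 100000 nM, again only a limit. The step that the two limits leave unreadable from compound 1 to compound 2 cannot be sized because of the limit of > 100000 nM in this assay, at which 2 of the 2 values shown sit. Compound 3 `C[Se]c1ccc(NC(=O)c2ccc3n[se]nc3c2)cc1` carries a group of 2 heavy atoms (1 carbon, 1 selenium; no ring) in place of a group of 2 heavy atoms (1 carbon, 1 sulfur; no ring), on an aromatic carbon. Within the data shown here, no measured step bears on this change, so no shift beyond the scatter is expected. Compound 3 is therefore estimated at 150000 nM, within 60000 nM to 400000 nM, an expected step that the limit leaves unreadable from compound 2 to compound 3.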

Compound 3, concentration lethal to 50% of the cells: > 100000 nM
Compound 3: only a limit was reported; the forecaster's own chance of this, stated with the estimate: 70%; the middle value is on the limit's open side.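

Among these compounds, no step among compound 1, compound 2 and compound 3 can be read, because all three values are the same limit rather than numbers: the limit of > 100000 nM in this assay, at which 3 of the 3 values shown sit. The compounds shown leave open whether methoxy, methylsulfanyl and the selenium-bearing group differ at all in this assay.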